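The source may report more compounds than this note shows. Statements on the series, on what has been measured and on what is new or still open speak of the compounds shown alone.

Compound 1, `COc1cc(-c2cc(C(=O)O)c3ccccc3n2)ccc1OCC(=O)Nc1ccccc1`, gives 0.7.
Compound 2, `COc1cc(-c2cc(C(=O)O)c3ccccc3n2)ccc1OCC(=O)Nc1ccccc1C`, gives 0.8.
Compound 3, `COc1cc(-c2cc(C(=O)O)c3ccccc3n2)ccc1OCC(=O)Nc1ccc(C)cc1`, gives 1.2.

These three compounds share one core and differ only in the ring attached to the amide nitrogen. In a physicochemical assay for lipophilicity, using the shake flask method, in phosphate buffer, measured as octanol-water partition, at pH 7.4 (on this read-out lower numbers stand for lower lipophilicity and higher numbers for higher lipophilicity), compound 3 stands highest of the three; its nearest neighbour is compound 2, with a number 0.40 log units higher from compound 2 to compound 3 (beyond the scatter), and the furthest is compound 1, with a number 0.50 log units higher from compound 1 to compound 3 (beyond the scatter).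

Compound 4, `COc1cc(-c2cc(C(=O)O)c3ccccc3n2)ccc1OCC(=O)Nc1cccc(F)c1`, is the next member. The change from compound 3 is 3-fluorophenyl in place of 4-methylphenyl on an amide-type nitrogen. Within the data shown here, two measured steps bear on it. The step of a number 0.50 log units higher from compound 1 to compound 3 (beyond the scatter) shows what the methyl of the 4-methylphenyl ring alone contributes, and that methyl is taken away here. The step of a number 0.40 log units higher from compound 2 to compound 3 (beyond the scatter) shows how much moving the same methyl around the ring can matter. Among the measured compounds shown here, no measured step covers a fluorine on this ring, so that part is open. Taking away the methyl should pull the number back towards compound 1, and the fluorine is expected to offset only a small part of that, so a modest downward step is expected: a number 0.30 log units lower from compound 3 to compound 4 (within the scatter). Compound 4 is therefore estimated at 0.9, with a likely range from 0.5 to 1.3.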

Compound 4, distribution coefficient: 1.6
Compound 4: middle estimate off by 0.70 log units, on the low side; the measured number lies above the stated range.
By their numbers in this assay, from the lowest: compounds 1 and 2 (each within the scatter of the next); then compound 3; then compound 4.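

Putting fluoro in place of hydrogen on the ring at the amide nitrogen gives a number 0.90 log units higher from compound 1 to compound 4 (beyond the scatter) in this assay, a larger step than either methyl gave on that ring. The 3-fluorophenyl group also lies beyond both methyl-bearing rings, with a number 0.40 log units higher from compound 3 to compound 4 (beyond the scatter) and a number 0.80 log units higher from compound 2 to compound 4 (beyond the scatter), although 3-fluorophenyl and 4-methylphenyl have the same heavy-atom count, so that count alone does not set the number here. Nothing available explains why this fluoro-bearing compound stands highest of the four.

The compounds shown leave open whether fluoro would give a similar step at another place on this ring. They also leave open how a chlorine, an amine or a carboxylic acid on this ring would compare.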